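Permeability in a Small Quinoline Series: Estimating Compound 3

The source may report more compounds than this note shows. Statements on the series, on what has been measured and on what is new or still open speak of the compounds shown alone.

Compound 1, `COc1cccc(CNCCCNc2ccnc3cc(Oc4ccc(F)cc4)ccc23)c1O`: 317 10^-6 cm/s
Compound 2, `COc1cccc(CNCCCNc2ccnc3cc(Cc4ccc(C#N)cc4)ccc23)c1O`: 23 10^-6 cm/s

Both compounds were measured in an ADME assay for permeability, using PAMPA, with a stated time of 30 min, at pH 7.4; on this read-out higher numbers stand for higher permeability and lower numbers for lower permeability. Within the data shown here, compound 2 holds the lower of the two numbers, and the single step that separates it from compound 1 is a 14-fold lower number from compound 1 to compound 2 (1.14 log units; beyond the scatter), a large change well outside the usual scatter. Compound 3, `COc1cccc(CNCCCNc2ccnc3cc(-c4ccc(C(F)(F)F)cc4)ccc23)c1O`, has not yet been measured. It differs from compound 2 in one place: 4-(trifluoromethyl)phenyl in place of 4-cyanobenzyl on an aromatic carbon. Among the measured compounds shown here, the only measured step that bears on this change is the one that introduced the 4-cyanobenzyl group, a 14-fold lower number from compound 1 to compound 2 (1.14 log units; beyond the scatter). Compound 3 removes that group again, so a step upward beyond the scatter is expected, on the order of a 6.5-fold higher number from compound 2 to compound 3 (0.81 log units; beyond the scatter). Compound 3 is therefore estimated to give 150 10^-6 cm/s in this assay, with a plausible range from 40 10^-6 cm/s to 400 10^-6 cm/s.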

Compound 3, apparent permeability: 237 10^-6 cm/s
The estimate for compound 3 lay 1.6-fold (0.20 log units) below the measured number, within the range that was stated.
By their numbers in this assay, from the lowest: compound 2; then compounds 3 and 1 (each within the scatter of the next).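

In this assay, replacing the 4-cyanobenzyl group with 4-(trifluoromethyl)phenyl on this aromatic carbon gives a 10-fold higher number from compound 2 to compound 3 (1.01 log units; beyond the scatter). Replacing 4-fluorophenoxy with the same group gives a 1.3-fold lower number from compound 1 to compound 3 (0.13 log units; within the scatter), so this position can hold two quite different groups with no change beyond the scatter, and among these three compounds only the 4-cyanobenzyl group goes with a low number. No measurement shown here gives a reason for this difference.

The step from compound 2 to compound 3 swaps the nitrile for trifluoromethyl and a benzyl for a phenyl at the same time, so the compounds shown cannot tell which of the two matters. A 4-cyanophenyl group at this position would separate them, while an amine or a carboxylic acid here remains an open case.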